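Dienone-chromone series: notes toward compound 3

A few compounds are considered here, and "the series" means these few. Any claim that something is new, unique, unknown or untested is made for them only; others in the source may bear on it.

Measured so far:
compound 1, `O=C(/C=C/c1ccc(Cl)cc1)/C=C/c1ccc(Oc2cc(=O)oc3ccccc23)cc1` — a functional assay on MGC-803 cells (Homo sapiens) for antiproliferative activity, read by MTT assay, with a stated time of 48 h; on this read-out lower numbers stand for stronger inhibition and higher numbers for weaker inhibition: 55200 nM
compound 2, `COc1cc(OC)c2c(=O)c(OCCCOc3ccccc3/C=C/C(=O)/C=C/c3ccccn3)c(-c3cc(OC)c(OC)c(OC)c3)oc2c1` — this assay: 560 nM

Compound 2 holds the lower of the two numbers in this assay; compound 1 returns a far higher number, and that gap lies beyond the scatter of the read-out. The two differ in many places at once, so nothing can be read from the pair about any single group.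

Compound 3, `COc1cc(OC)c2c(=O)c(OCCCOc3ccccc3/C=C/C(=O)/C=C/c3cccc([N+](=O)[O-])c3)c(-c3cc(OC)c(OC)c(OC)c3)oc2c1`, is the next analogue and is still to be measured. Its change from compound 2 is 3-nitrophenyl in place of pyridin-2-yl on a double-bonded chain carbon bound to a double-bonded chain carbon. Going by the values given here, no step between measured compounds that differ in one place exists in this set, so the size of the change is not anchored by the data. A step of moderate size is expected in this assay, with the number for compound 3 more likely somewhat higher than lower, and possibly within the scatter. For compound 3 the expected step is a 1.3-fold higher number from compound 2 to compound 3 (0.13 log units; within the scatter). Compound 3 is estimated at 750 nM, with a range from 250 nM to 2500 nM.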

Compound 3, half-maximal inhibitory concentration: 5730 nM
Compound 3: the middle estimate sits 7.6-fold (0.88 log units) below what was measured; measured number above the stated range.
By their numbers in this assay, from the lowest: compound 2; then compound 3; then compound 1.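

Going by these compounds alone, this is the first step that changes one place with the rest of the structure held constant: on a double-bonded chain carbon bound to a double-bonded chain carbon, 3-nitrophenyl in place of pyridin-2-yl gives a 10-fold higher number from compound 2 to compound 3 (1.01 log units; beyond the scatter) in this assay. The number in this assay therefore responds strongly to the group at this place, which the pair of compound 1 and compound 2, differing in many places at once, could not show. No measurement at hand accounts for the size of this step.

A single pair cannot separate what leaving pyridin-2-yl contributes from what entering 3-nitrophenyl contributes. Also open, going by these compounds, is whether plain phenyl or 3-aminophenyl at this place would give a number closer to that of compound 2 or to that of compound 3.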